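Adding an Amino Group to the Acetamide Analogue

The compounds below may be only part of what the source reports. "The series", "measured", "known", "first", "only" and "open" are said of these compounds alone.

Measured in an assay on HEK293 cells for displacement of a labelled ligand from Melanocortin receptor 4 (Homo sapiens); a higher number here means a weaker inhibitor, a lower number a stronger inhibitor:
compound 1 `CCN[C@H](c1cc(C(F)(F)F)ccc1N1CCN(C(=O)CCc2ccc(Cl)cc2Cl)CC1)C(C)CC`: 92 nM
compound 2 `CCC(C)[C@H](NCCN)c1cc(C(F)(F)F)ccc1N1CCN(C(=O)CCc2ccc(Cl)cc2Cl)CC1`: 56 nM
compound 3 `CCC(C)[C@H](NC(C)=O)c1cc(C(F)(F)F)ccc1N1CCN(C(=O)CCc2ccc(Cl)cc2Cl)CC1`: 360 nM

Compound 3 differs from compound 1 by acetyl in place of ethyl on an amine nitrogen, and in this assay this gave a 3.9-fold higher number from compound 1 to compound 3 (0.59 log units; beyond the scatter). Compound 4 `CCC(C)[C@H](NC(=O)CN)c1cc(C(F)(F)F)ccc1N1CCN(C(=O)CCc2ccc(Cl)cc2Cl)CC1` is not yet measured. It arises from compound 3 by amino in place of hydrogen on a saturated chain carbon bound to a carbonyl carbon. The same kind of change, (amino in place of hydrogen on a saturated chain carbon, two bonds along the chain from an amine nitrogen), was made from compound 1 to compound 2, where it gave a 1.6-fold lower number from compound 1 to compound 2 (0.22 log units; within the scatter). The two places are not the same: in one case the carbon is two bonds along the chain from an amine nitrogen, in the other it is bound to a carbonyl carbon, so the earlier step is only a rough guide. Compound 4 is therefore expected to show a 1.4-fold lower number from compound 3 to compound 4 (0.14 log units; within the scatter), resting on the small step from compound 1 to compound 2. The estimate for compound 4 is 260 nM, between 100 nM and 700 nM.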

Compound 4, inhibition constant: 18 nM
Compound 4: the middle estimate sits 14-fold (1.16 log units) above what was measured; the whole stated range lies above it.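

In this assay the amino group gave a 20-fold lower number from compound 3 to compound 4 (1.30 log units; beyond the scatter), and the other two comparisons point the same way, with a 3.1-fold lower number from compound 2 to compound 4 (0.49 log units; beyond the scatter) and a 5.1-fold lower number from compound 1 to compound 4 (0.71 log units; beyond the scatter). Set beside the earlier step, the same change did not carry over in size from one core to the other: the same change on two cores in this assay, a 1.6-fold lower number (0.22 log units; within the scatter) from compound 1 to compound 2 and a 20-fold lower number (1.30 log units; beyond the scatter) from compound 3 to compound 4, 12-fold (1.09 log units) apart, beyond the scatter of two such steps. This single pair shows that the size of the step depends on the core in this series, but it does not show why, or how the change would behave on any further core.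

The compounds shown leave open whether a longer chain carrying the amine, or a dimethylamino group in place of the amino group, would keep this lower number in this assay.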